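This account rests on a few compounds, and the source may have more. Where it says the series, first, only, none or still open, it means among the compounds named here.

Measured so far:
Compound 1, `CN(C)C(=S)N/N=C/c1ccc2ccccc2n1`: 90 nM
Compound 2, `NC(=S)N/N=C/c1ccc2cccnc2n1`: > 100000 nM
Compound 3, `NC(=S)N/N=C/c1nc2ccccc2s1`: 5350 nM

These three compounds share a thiocarbonyl-bearing hydrazone side chain attached to a bicyclic core, and all were tested in a functional assay on HeLa cells (Homo sapiens) for antiproliferative activity, read by sulforhodamine B assay, with a stated time of 72 h; a higher number here means a weaker inhibitor, a lower number a stronger inhibitor. Compound 1 has the lowest number of the values that are actual numbers; in this assay compound 1 gives 90 nM. The nearest measured value belongs to compound 3, which gives 5350 nM in this assay, a gap well beyond the usual scatter. Compound 2 is different in kind: its value of > 100000 nM is a limit of this assay, not a number, so it only tells that no inhibition was seen down to that concentration (the limit of > 100000 nM in this assay, at which 1 of the 3 values shown sits).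

Compound 4, `NC(=S)N/N=C/c1ccc2ccccc2n1`, keeps the core of compound 1 and alters only the thiocarbonyl end: amino in place of dimethylamino on a thiocarbonyl carbon. Among the measured compounds shown here, no pair of measured compounds differs in exactly this way, so the size of the step is open. Both compounds that carry the plain amino group, compound 2 and compound 3, show weaker or undetected activity than compound 1, but their cores also differ, so this is a hint rather than a rule. Compound 4 is therefore expected to be weaker than compound 1, with a step of a 33-fold higher number from compound 1 to compound 4 (1.52 log units; beyond the scatter) in this assay. The estimate for compound 4 in this assay is 3000 nM, within a range from 400 nM to 25000 nM.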

Compound 4, half-maximal inhibitory concentration: 960 nM
Compound 4: middle estimate off by 3.1-fold (0.49 log units), on the high side; measured number inside the range.
By their numbers in this assay, from the lowest: compound 1; then compound 4; then compound 3. At a limit, above all of these: compound 2.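

Among the compounds shown here, this is the first pair in the set that differs in one place only, so the thiocarbonyl end can now be judged apart from any change in the core: amino in place of dimethylamino on a thiocarbonyl carbon gives an 11-fold higher number from compound 1 to compound 4 (1.03 log units; beyond the scatter) in this assay. The place is therefore sensitive, since a change confined to this end, with the shared core untouched, moves the number well beyond the usual scatter, and the lower number belongs to the compound that carries dimethylamino. The dimethylamino group is still not needed for a measurable effect on this core, as compound 4 gives 960 nM and not a limit.

The compounds shown leave open how a methylamino group, a diethylamino group or a ring amine such as pyrrolidine would fare at this place, and whether the step would keep its size on another core. Nothing shown gives a reason for the size of this step.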